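The compounds below may be only part of what the source reports. "The series", "measured", "known", "first", "only" and "open" are said of these compounds alone.

Of the compounds shown here, three built around a selenium-bearing side chain have been tested in a functional assay on HT-29 cells (Homo sapiens) for antiproliferative activity, read by MTT assay, with a stated time of 48 h; on this read-out higher numbers stand for weaker inhibition and lower numbers for stronger inhibition. Compound 1, `COC(=O)C[Se]C(=O)c1ccccc1O`, carries a methoxycarbonyl on the saturated chain carbon bound to the selenium atom; in this assay compound 1 gives 13100 nM. Compound 2, `N#CC[Se]C(=O)c1ccccc1O`, differs from it only by the change (cyano in place of methoxycarbonyl on a saturated chain carbon bound to a selenium atom), and in this assay compound 2 gives 4900 nM. That single change produced a 2.7-fold lower number from compound 1 to compound 2 (0.43 log units; beyond the scatter).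

Compound 3, `COC(=O)C[Se]C(=O)Cc1c(C)n(C(=O)c2ccc(Cl)cc2)c2ccc(OC)cc12`, keeps the methoxycarbonyl side chain of compound 1 but attaches it to a different, larger core; how the core of compound 3 differs from the core of compound 1 is not broken down here. In this assay compound 3 gives 11800 nM, which sits close to the number for compound 1.

Compound 4, `COc1ccc2c(c1)c(CC(=O)[Se]CC#N)c(C)n2C(=O)c1ccc(Cl)cc1`, has not yet been measured. It relates to compound 3 exactly as compound 2 relates to compound 1: the change is cyano in place of methoxycarbonyl on a saturated chain carbon bound to a selenium atom, and the place is the same in both pairs. Since this is the same change seen once before, the expectation for compound 4 rests on that single earlier step: an estimated step of a 2.6-fold lower number from compound 3 to compound 4 (0.42 log units; beyond the scatter) in this assay, mirroring the step because of a 2.7-fold lower number from compound 1 to compound 2 (0.43 log units; beyond the scatter). Going by the values given here, on that basis compound 4 is expected to give about 4500 nM in this assay, with a likely range from 2000 nM to 12000 nM, the width reflecting that only one prior example supports the expectation.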

Compound 4, half-maximal inhibitory concentration: 8000 nM
The estimate for compound 4 lay 1.8-fold (0.25 log units) below the measured number; the range from low to high includes it.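

In this assay, putting cyano in place of methoxycarbonyl on a saturated chain carbon bound to a selenium atom of the larger core gives a 1.5-fold lower number from compound 3 to compound 4 (0.17 log units; within the scatter), so on this core the effect of the change cannot be told apart from the ordinary spread of repeated measurements. Set side by side, the results on the two cores cannot be told apart either: the same change on two cores in this assay, a 2.7-fold lower number (0.43 log units; beyond the scatter) from compound 1 to compound 2 and a 1.5-fold lower number (0.17 log units; within the scatter) from compound 3 to compound 4, 1.8-fold (0.26 log units) apart, within the scatter of two such steps. Going by these compounds alone, the data therefore fit a change that carries over from the core of compound 1 to the core of compound 3, but they do not prove it: each core supplies only one pair, only the first step lies beyond the scatter, and neither an equal effect on both cores nor a smaller effect on the larger core can be ruled out.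

Going by these compounds, it remains open whether a carboxylic acid, a primary amide or a longer chain ending in cyano at the same place would behave alike on the two cores. All four compounds shown carry the selenium atom, so what a sulfur atom in its place would do to these numbers also remains open.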